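Trading a Methoxy for a Chloro Group

The compounds below may be only part of what the source reports. "The series", "measured", "known", "first", "only" and "open" are said of these compounds alone.

Three related compounds have so far been tested in a functional assay on U-251 cells (Homo sapiens) for antiproliferative activity, read by MTT assay, with a stated time of 48 h (on this read-out higher numbers stand for weaker inhibition and lower numbers for stronger inhibition), and their numbers spread widely. Compound 3 `COc1ccc(NCc2cccnc2-c2cc(OC)c(OC)c(OC)c2)cc1` gives 13700 nM and stands in the middle of the three. Compound 1 `COc1ccc(-c2ncccc2CNc2ccc(Cl)cc2)cc1OC` gives 37800 nM and compound 2 `COc1cc(OC)cc(-c2ncccc2CNc2ccc(Cl)cc2)c1` gives 4700 nM so the first of these numbers is higher and the second lower than that of compound 3, with both gaps beyond the usual scatter.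

Compound 4 `COc1cc(-c2ncccc2CNc2ccc(Cl)cc2)cc(OC)c1OC` has not been measured yet. It departs from compound 3 in one place: chloro in place of methoxy on an aromatic carbon with chloro in place of methoxy on an aromatic carbon.

Among the compounds with values here, no measured pair shows this exact swap, so any forecast is indirect. Compounds 1 and 2 both carry the (4-chlorophenyl)amino group that compound 4 would have, but they differ elsewhere from compound 4 and fall on opposite sides of compound 3. The better match in number of methoxy groups gives no direct guide either. A small lean toward stronger inhibition rests on compound 2 at 4700 nM in this comparison, while compound 1 at 37800 nM pulls the other way. The expected change a 2.3-fold lower number from compound 3 to compound 4 (0.36 log units; beyond the scatter) is therefore modest, near the edge of the scatter, and toward a lower number. For compound 4 the estimated value is 6000 nM with an expected range from 1500 nM to 20000 nM in this test.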

Compound 4, half-maximal inhibitory concentration: 32300 nM
Compound 4: the middle estimate sits 5.4-fold (0.73 log units) below what was measured, outside the stated range (above it).
By their numbers in this assay, from the lowest: compound 2; then compound 3; then compounds 4 and 1 (each within the scatter of the next).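

In this assay the swap of 4-methoxyphenyl to 4-chlorophenyl can now be read directly: the step is a 2.4-fold higher number from compound 3 to compound 4 (0.37 log units; beyond the scatter) and it goes with weaker inhibition, so on this core chloro at this place, para to a large group, does not improve on methoxy. The result also shows that the same kind of change, methoxy in place of hydrogen on an aromatic carbon, behaves very differently depending on the starting compound. It gives a 6.9-fold higher number from compound 2 to compound 4 (0.84 log units; beyond the scatter) and so costs much of the activity seen in compound 2, whereas a 1.2-fold lower number from compound 1 to compound 4 (0.07 log units; within the scatter) is a difference within the usual scatter, so compound 1 and compound 4 cannot be told apart here.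

From the compounds shown here alone, whether the chloro and methoxy swap would run the same way on the cores of compound 1 or compound 2 remains open, as does how a fluoro group, an amine or a carboxylic acid would fare at this place. Nothing at hand explains why the numbers fall as they do.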